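Opening the Ring and Restoring a Hydroxyl on the Amide

The compounds below may be only part of what the source reports. "The series", "measured", "known", "first", "only" and "open" are said of these compounds alone.

Of the compounds shown here, three built on one shared core have been tested in an assay on HEK293 cells for displacement of a labelled ligand from NPC1-like intracellular cholesterol transporter 1 (Homo sapiens); a higher number here means a weaker inhibitor, a lower number a stronger inhibitor. Compound 1 `O=C(CN1CN(c2ccccc2)C2(CCN(C(=O)c3ccc(C4CCCCC4)cc3)CC2)C1=O)N1CCC(CO)CC1` gives 1100 nM. Compound 2 `COC(=O)CCCNC(=O)CN1CN(c2ccccc2)C2(CCN(C(=O)c3ccc(C4CCCCC4)cc3)CC2)C1=O` gives 2500 nM, and compound 3 `CC1CCCN(C(=O)CN2CN(c3ccccc3)C3(CCN(C(=O)c4ccc(C5CCCCC5)cc4)CC3)C2=O)C1` gives 3600 nM. Compound 3 thus sits at the upper end of these numbers: there is a 3.3-fold higher number from compound 1 to compound 3 (0.51 log units; beyond the scatter), whereas a 1.4-fold higher number from compound 2 to compound 3 (0.16 log units; within the scatter).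

Compound 4 `O=C(CN1CN(c2ccccc2)C2(CCN(C(=O)c3ccc(C4CCCCC4)cc3)CC2)C1=O)NCCCCO` differs from compound 3 in one place: (4-hydroxybutyl)amino in place of 3-methylpiperidin-1-yl on a carbonyl carbon. Two of the measured steps speak to this change. The step from compound 1 to compound 3 removed a hydroxyl group and raised the number beyond the scatter, while the step from compound 2 to compound 3 swapped an open chain for a ring and stayed within it. Putting a hydroxyl back on an open chain is therefore expected to move the number downward by a modest amount, a 2.0-fold lower number from compound 3 to compound 4 (0.30 log units; within the scatter). Compound 4 is expected to give about 1800 nM in this assay, with a likely range from 700 nM to 4500 nM.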

Compound 4, half-maximal inhibitory concentration: 10300 nM
Compound 4: the middle estimate sits 5.7-fold (0.76 log units) below what was measured; measured number above the stated range.
By their numbers in this assay, from the lowest: compound 1; then compounds 2 and 3 (each within the scatter of the next); then compound 4.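

On this carbonyl carbon, a hydroxyl on an open chain does not bring the number down: (4-hydroxybutyl)amino in place of 3-methylpiperidin-1-yl gives a 2.9-fold higher number from compound 3 to compound 4 (0.46 log units; beyond the scatter), and in place of 4-(hydroxymethyl)piperidin-1-yl it gives a 9.4-fold higher number from compound 1 to compound 4 (0.97 log units; beyond the scatter), even though both groups carry a hydroxyl. Within the open chains, hydroxymethyl in place of methoxycarbonyl gives a 4.1-fold higher number from compound 2 to compound 4 (0.61 log units; beyond the scatter), so among these compounds a hydroxyl goes with the lowest number only on the ring of compound 1, and compound 4 goes against any rule that a hydroxyl lowers it. Nothing available here explains these steps.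

Still open, going by these compounds, is how the chain behaves when its end carries a carboxylic acid or an amine instead of the hydroxyl. A longer chain ending in hydroxyl, or a plain butyl chain with no oxygen, would show whether the chain itself or its end group sets the number.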